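This account rests on a few compounds, and the source may have more. Where it says the series, first, only, none or still open, it means among the compounds named here.

Compound 3 `Cn1cncc1C(OCc1ccc(C#N)nc1-c1ccccc1)c1ccc(C#N)cc1` reaches in an assay on isolated protein (Bos taurus) for inhibition of geranylgeranyl transferase type-1 subunit beta (Homo sapiens) (on this read-out higher numbers stand for weaker inhibition and lower numbers for stronger inhibition), only a limit, > 10 nM, and no number. Its neighbours in the series carry numbers: compound 1 `Cn1cncc1C(OCc1ccc(C#N)nc1-c1ccc(OC(F)(F)F)cc1)c1ccc(C#N)cc1` gives in this assay 1200 nM, and compound 2 `Cn1cncc1C(OCc1ccc(C#N)nc1-c1ccc2ccccc2c1)c1ccc(C#N)cc1` gives 5500 nM. Of the steps that end at compound 3, a step that the limit leaves unreadable from compound 1 to compound 3 and a step that the limit leaves unreadable from compound 2 to compound 3, so the limit of > 10 nM in this assay, at which 1 of the 3 values shown sits, settles nothing about where compound 3 would sit among the numbers. Among the compounds with values here, the only readable step in the set, a 4.6-fold higher number from compound 1 to compound 2 (0.66 log units; beyond the scatter), changes the same aromatic carbon but with a different pair of groups, neither of them carrying chlorine. Compound 4 `Cn1cncc1C(OCc1ccc(C#N)nc1-c1cc(Cl)cc(Cl)c1)c1ccc(C#N)cc1` differs from compound 3 by 3,5-dichlorophenyl in place of phenyl on an aromatic carbon. Within the data shown here, no measured step covers chlorine on this ring, and the starting point is itself a limit, so the expectation rests on little more than the span that compounds 1 and 2 mark out. The step that the limit leaves unreadable from compound 3 to compound 4 is therefore expected to remain modest. Compound 4 is expected to come out near 2000 nM, with a likely range from 400 nM to 10000 nM.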

Compound 4, half-maximal inhibitory concentration: 1400 nM
For compound 4 the middle estimate is 1.4-fold (0.15 log units) above the measured one, and the stated range covers the measured number.
By their numbers in this assay, from the lowest: compounds 1 and 4 (each within the scatter of the next); then compound 2.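

At this aromatic carbon, 3,5-dichlorophenyl and 4-(trifluoromethoxy)phenyl cannot be told apart in this assay, with a 1.2-fold higher number from compound 1 to compound 4 (0.07 log units; within the scatter). Naphthalen-2-yl stands apart from 3,5-dichlorophenyl, with a 3.9-fold lower number from compound 2 to compound 4 (0.59 log units; beyond the scatter), so among compounds 1, 2 and 4 the two substituted phenyl groups give matching numbers and naphthalen-2-yl gives the higher one. Compound 3 carries only a limit, so its step to compound 4 cannot be read and what the two chlorines add to plain phenyl stays unknown: the limit of > 10 nM in this assay, at which 1 of the 4 values shown sits.

Still open, going by these compounds, is whether a single chlorine on the phenyl gives the same number as the 3,5-dichlorophenyl of compound 4. Also open is how an amine or a carboxylic acid on that phenyl would read in this assay, since every group shown here is free of both.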